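Moving the ring nitrogen on the hydrazone end

The compounds below may be only part of what the source reports. "The series", "measured", "known", "first", "only" and "open" are said of these compounds alone.

Measured compounds:
Compound 1 `CN(C)c1ccc(/C=N/NC(=O)c2cccnc2Nc2cccc(C(F)(F)F)c2)cc1` gives 63.5% in a functional assay on the whole organism (strain Wistar) for inhibition, with Rattus norvegicus as the target, read by paw edema, with a stated time of 1 h, at a dose of 10 mg/kg by the intraperitoneal route; on this read-out higher numbers stand for more inhibition at the one dose given (going by the name of the read-out) and lower numbers for less inhibition.
Compound 2 `O=C(N/N=C/c1cccnc1)c1cccnc1Nc1cccc(C(F)(F)F)c1` gives 76.1% in this assay.

In this assay compound 2 stands highest of the two numbers at hand; its nearest neighbour is compound 1, and the step of a number 12.6 percentage points higher from compound 1 to compound 2 (beyond the scatter) lies beyond the scatter.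

Compound 3 `O=C(N/N=C/c1ccncc1)c1cccnc1Nc1cccc(C(F)(F)F)c1` is not yet measured. It is made from compound 2 by the change (pyridin-4-yl in place of pyridin-3-yl on a carbon with a double bond to nitrogen), so the two have the same atoms joined differently; the ring nitrogen moves within the pyridinyl group attached to the carbon with a double bond to nitrogen.

For the measured compounds named here, the only measured step, a number 12.6 percentage points higher from compound 1 to compound 2 (beyond the scatter), swaps a 4-(dimethylamino)phenyl for a pyridin-3-yl at that same place; it does not show what a shift of the nitrogen inside a pyridinyl ring does. Going by the values given here, no measured step bears directly on the change to compound 3. The expectation is therefore a step within the scatter, in no clear direction, that is a number 4.1 percentage points lower from compound 2 to compound 3 (within the scatter).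

Compound 3 is expected to give about 72% in this assay, with a range from 55% to 85%.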

Compound 3, a percentage reported as inhibition, in the whole organism at one dose (the size of the read-out at that dose, not a potency): 70.2%
Compound 3: middle estimate off by 1.8 percentage points, on the high side, and the stated range covers the measured number.
By their numbers in this assay, from the lowest: compounds 1, 3 and 2 (each within the scatter of the next, the first and the last beyond it).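

In this assay, shifting the ring nitrogen within the pyridinyl group on the carbon with a double bond to nitrogen gives a number 5.9 percentage points lower from compound 2 to compound 3 (within the scatter) and so leaves pyridin-3-yl and pyridin-4-yl indistinguishable at this place. Replacing 4-(dimethylamino)phenyl with pyridin-4-yl gives a number 6.7 percentage points higher from compound 1 to compound 3 (within the scatter) and therefore does not clearly repeat the gain beyond the scatter seen earlier with pyridin-3-yl, although the small gap between compound 2 and compound 3 means this contrast should not be read as a real effect of where the ring nitrogen sits. No measurement at hand accounts for any of these numbers or shows what the ring nitrogen does here.

As far as these compounds go, it remains open how pyridin-2-yl or an unsubstituted phenyl would compare at this carbon, and so whether a ring nitrogen is needed at all for the higher number of compound 2. Each number also gives the size of the effect at a single dose and time, so these compounds leave their relative potency unsettled.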